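Methyl in Place of Acetamido on the Shared Core

The source may hold more compounds than are shown below. What is called first, only, known or untested is meant among the compounds shown, and "the series" means these compounds.

In a functional assay on HCT-15 cells (Homo sapiens) for inhibition, read by sulforhodamine B assay (a lower number here means a stronger inhibitor of growth, a higher number a weaker inhibitor of growth), compound 1 (`COc1cccc(CN2CCC=C(CCC(=O)NO)C2=O)c1`) gives 9030 nM and compound 2 (`O=C(CCC1=CCCN(Cc2ccc(F)cc2)C1=O)NO`) gives 9960 nM as its result, and these two values lie within the usual scatter of each other. Compound 3 (`CC(=O)Nc1ccc(CN2CCC=C(CCC(=O)NO)C2=O)cc1`) has no single number, since its entry reads "not determined" (no result reported) and so offers no starting value. Compound 4 (`Cc1ccc(CN2CCC=C(CCC(=O)NO)C2=O)cc1`) carries methyl in place of acetamido on an aromatic carbon, para to a large group (methyl in place of acetamido on an aromatic carbon). Among the compounds with values here, no measured step from compound 3 can be given, so the expectation rests on compound 1 and compound 2 alone, and compound 4 is expected to show no difference from them beyond the scatter in this assay in either direction. For compound 4 the estimate is 9000 nM (expected range 4500 nM to 18000 nM).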

Compound 4, concentration for 50% growth inhibition: 8510 nM
Beside the measured number, compound 4's estimate is 1.1-fold (0.02 log units) above it; the measured number falls inside the stated range.
By their numbers in this assay, from the lowest: compounds 4, 1 and 2 (each within the scatter of the next).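

In this assay, methyl in place of fluoro on an aromatic carbon, para to a large group, gives a 1.2-fold lower number from compound 2 to compound 4 (0.07 log units; within the scatter), so the two groups cannot be told apart at this position. The change from acetamido to methyl itself cannot be read: compound 3 has no single number. Nothing on hand explains these results. The compounds shown leave open whether an amine, a carboxylic acid or a longer chain on this aromatic carbon would shift the number beyond the scatter.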